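Hexyl in place of phenyl on compound 2's ether oxygen

A few compounds are considered here, and "the series" means these few. Any claim that something is new, unique, unknown or untested is made for them only; others in the source may bear on it.

Going by the values given here, compound 2 `O=C1OCCN1C(=O)c1ccc(Oc2ccccc2)cc1` has the lowest of the two numbers so far in an assay on HEK293 cells for inhibition of N-acylethanolamine-hydrolyzing acid amidase (Rattus norvegicus), read by LC-MS, with a stated time of 30 min (a higher number here means a weaker inhibitor, a lower number a stronger inhibitor), where compound 2 gives 680 nM. Compound 1 `O=C(CCCCCc1cccc(I)c1)N1CCOC1=O` gives 3120 nM in this assay. Compound 3 `CCCCCCOc1ccc(C(=O)N2CCOC2=O)cc1` differs from compound 2 by hexyl in place of phenyl on an oxygen on an aromatic ring. No step between two measured compounds bears on this change, so no direction can be read from a shown step. He expects the step from compound 2 to compound 3 to be a small rise, a 1.5-fold higher number from compound 2 to compound 3 (0.17 log units; within the scatter), possibly within the scatter. His estimate for compound 3 in this assay is 1000 nM, within 300 nM to 3500 nM.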

Compound 3, half-maximal inhibitory concentration: 640 nM
Compound 3: middle estimate off by 1.6-fold (0.19 log units), on the high side, and the stated range covers the measured number.
By their numbers in this assay, from the lowest: compounds 3 and 2 (each within the scatter of the next); then compound 1.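

Hexyl in place of phenyl on this oxygen gives a 1.1-fold lower number from compound 2 to compound 3 (0.03 log units; within the scatter) in this assay. At this place, then, an open chain of the same heavy-atom count reads the same as the aromatic ring, so in this pair the ring is not needed to hold the number. Nothing given here accounts for the two groups reading alike. Still open, going by these compounds, is how far the chain length can move, with butyl or a longer chain such as decyl on the same oxygen. Also open, on these data alone, is whether a carboxylic acid or an amine on the chain would be tolerated.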